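One side-chain swap, and only a limit to start from

The source may hold more compounds than are shown below. What is called first, only, known or untested is meant among the compounds shown, and "the series" means these compounds.

- Compound 1 `CC(C)NCCOc1c(O)cc(O)c2c(=O)cc(-c3ccccc3)oc12`: "not determined" (no result reported)
- Compound 2 `CC(CO)NCCOc1c(O)cc(O)c2c(=O)cc(-c3ccccc3)oc12`: "not determined" (no result reported)
- Compound 3 `CN1CCN(CCCOc2c(O)cc(O)c3c(=O)cc(-c4ccccc4)oc23)CC1`: > 100000 nM (a limit, not a number)

These three compounds share one core and differ in the chain attached through an oxygen on an aromatic ring. The test here is a functional assay on A549 cells (Homo sapiens) for cytotoxicity, read by MTT assay, with a stated time of 48 h; a higher number here means a weaker inhibitor, a lower number a stronger inhibitor. Going by the values given here, compound 1 and compound 2 have no result, so there is no measured step to learn from. In this assay compound 3 gives > 100000 nM, which is a limit of the assay and not a number. The evidence therefore amounts to the limit of > 100000 nM in this assay, at which 1 of the 3 values shown sits.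

Compound 4 `CN(C)CCCCOc1c(O)cc(O)c2c(=O)cc(-c3ccccc3)oc12` has not yet been measured. Its difference from compound 3 is (dimethylamino)methyl in place of 4-methylpiperazin-1-yl on a saturated chain carbon, three bonds along the chain from an oxygen on an aromatic ring. In words, this is (dimethylamino)methyl in place of 4-methylpiperazin-1-yl on a saturated chain carbon, three bonds along the chain from an oxygen on an aromatic ring. Cut one bond further out, 3-(4-methylpiperazin-1-yl)propyl becomes 4-(dimethylamino)butyl.

Taking compound 3 at its limit of > 100000 nM as the only anchor, a modest move toward a lower number is expected, and another limit is quite possible. The expected change is an at least 1.6-fold lower number from compound 3 to compound 4 (0.22 log units; that floor lies within the scatter). Compound 4 is estimated at 60000 nM, with an expected range of 15000 nM to 200000 nM.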

Compound 4, half-maximal inhibitory concentration: > 100000 nM
Compound 4 ended at the assay's limit (the forecaster's own chance of this, stated with the estimate: 45%); at least 1.6-fold (0.22 log units) between middle value and limit.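

Compound 3 and compound 4 both end at a limit of this assay, not at a number, so no step can be read between them. The compounds shown leave open whether any of these side chains gives a true number in this test, since the evidence still stops at one value: the limit of > 100000 nM in this assay, at which 2 of the 4 values shown sit.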